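Ester chain length and growth inhibition: working notes

This account rests on a few compounds, and the source may have more. Where it says the series, first, only, none or still open, it means among the compounds named here.

Compound 1 `C=C[C@@](C)(/C=C/c1ccc(OC(=O)CCC)cc1)CCC=C(C)C`: 54%
Compound 2 `C=C[C@@](C)(/C=C/c1ccc(OC(=O)CCCCC)cc1)CCC=C(C)C`: 54%
Compound 3 `C=C[C@@](C)(/C=C/c1ccc(OC(=O)CCCCCCC)cc1)CCC=C(C)C`: 62%

In a functional assay on THP-1 cells (Homo sapiens) for inhibition, with a stated time of 48 h, tested at 50 uM (a lower number here means less inhibition of growth, a higher number more inhibition of growth at the concentration tested), compound 3 gives 62%, within the scatter of the other two compounds. The measured steps along the chain are no change at the digits printed from compound 1 to compound 2 (within the scatter), a number 8 percentage points higher from compound 1 to compound 3 (within the scatter) and a number 8 percentage points higher from compound 2 to compound 3 (within the scatter). None of them leaves the scatter.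

Compound 4 `C=C[C@@](C)(/C=C/c1ccc(OC(=O)CCCCCCCCCCCCCCC)cc1)CCC=C(C)C` is the next case, with octyl in place of hydrogen on a saturated chain carbon, seven bonds along the chain from a carbonyl carbon. This extension is longer than the butyl and ethyl steps already measured, so the trend is being stretched and the range is kept wide. The expected step is a number 2 percentage points lower from compound 3 to compound 4 (within the scatter), with nothing beyond the scatter anticipated. For compound 4 the estimated value is 60%, with an expected range of 40% to 75%.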

Compound 4, percent growth inhibition at one concentration: 62%
For compound 4 the middle estimate is 2 percentage points below the measured one; measured number inside the range.
By their numbers in this assay, from the lowest: compounds 1, 2, 3 and 4 (each within the scatter of the next).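

In this assay, octyl in place of hydrogen on a saturated chain carbon, seven bonds along the chain from a carbonyl carbon, gives no change at the digits printed from compound 3 to compound 4 (within the scatter), so the series now reaches a far longer ester chain with its number still inside the scatter. Read from the shorter esters, the picture is the same: a number 8 percentage points higher from compound 2 to compound 4 (within the scatter) and a number 8 percentage points higher from compound 1 to compound 4 (within the scatter). Nothing available explains this flat response. From the compounds shown here alone, whether a terminal carboxylic acid or amine on the chain would leave the scatter remains open, as does the effect of an amide in place of the ester.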